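A few compounds are considered here, and "the series" means these few. Any claim that something is new, unique, unknown or untested is made for them only; others in the source may bear on it.

Compound 1 `Cn1c(=O)c2nc(-c3cccc(N)c3)[nH]c2n(C)c1=O` and compound 2 `Cc1cccc(-c2nc3c(=O)n(C)c(=O)n(C)c3[nH]2)c1` share one core and differ only on the aromatic ring. In an assay for binding affinity to adenosine receptor A1 (Bos taurus) (a lower number here means a stronger inhibitor, a higher number a weaker inhibitor), compound 1 gives 10 nM, and compound 2 gives 13 nM, the higher of the two numbers; the step of a 1.3-fold higher number from compound 1 to compound 2 (0.11 log units; within the scatter) lies within the scatter. Compound 3 `Cn1c(=O)c2nc(-c3cccc(O)c3)[nH]c2n(C)c1=O` carries the change (hydroxy in place of methyl on an aromatic carbon). Going by the values given here, only the step from compound 1 to compound 2 bears on it, and it was small, so no movement beyond the scatter is expected in this assay. Compound 3 is therefore expected at 11 nM, between 4 nM and 30 nM, an expected step of a 1.2-fold lower number from compound 2 to compound 3 (0.07 log units; within the scatter).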

Compound 3, half-maximal inhibitory concentration: 6 nM
For compound 3 the middle estimate is 1.8-fold (0.26 log units) above the measured one; the range from low to high includes it.
By their numbers in this assay, from the lowest: compounds 3, 1 and 2 (each within the scatter of the next, the first and the last beyond it).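

In this assay this place on the ring now shows a step beyond the scatter: hydroxy in place of methyl gives a 2.2-fold lower number from compound 2 to compound 3 (0.34 log units; beyond the scatter), a modest change, whereas the earlier swap of amino for methyl stayed within it. Hydroxy in place of amino gives a 1.7-fold lower number from compound 1 to compound 3 (0.22 log units; within the scatter), so compound 1 and compound 3 cannot be told apart here. No measurement at hand gives a reason for the step. The compounds shown leave open how a methoxy group, a carboxylic acid or a longer chain would read at this place.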